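This account rests on a few compounds, and the source may have more. Where it says the series, first, only, none or still open, it means among the compounds named here.

Working notes on the series. The shared core is that of compound 1 `CCCCCCCCCCCCCCCCCC(=O)Oc1ccc(COP(=O)(OCc2ccc(OC(=O)CCCC)cc2)OP(=O)(O)OP(=O)(O)OC[C@@H]2C=C[C@H](n3cc(C)c(=O)[nH]c3=O)O2)cc1`, whose terminal phosphate carries two substituted arms. In an ADME assay on tissue (CCRF-CEM cells, Homo sapiens) for pharmacokinetics, read by HPLC (a higher number here means that the compound lasts longer, a lower number that the compound disappears faster), compound 1 gives 3.3 h. Compound 3 `CCCCCCCCCCCCCCCCCC(=O)Oc1ccc(COP(=O)(OCc2ccc(C(=O)CCCCCCCCC)cc2)OP(=O)(O)OP(=O)(O)OC[C@@H]2C=C[C@H](n3cc(C)c(=O)[nH]c3=O)O2)cc1` also carries two arms on the terminal phosphate and gives 7.8 h in this assay. Compound 2 `CCCCCCCCCC(=O)c1ccc(COP(=O)(O)OP(=O)(O)OP(=O)(O)OC[C@@H]2C=C[C@H](n3cc(C)c(=O)[nH]c3=O)O2)cc1` carries a single arm. For compound 2 this assay reports only a limit, > 30 h, not a number, which is the limit of > 30 h in this assay, at which 1 of the 3 values shown sits. Compound 4 `CCCCCCCCCCCCCCCCCC(=O)c1ccc(COP(=O)(O)OP(=O)(O)OP(=O)(O)OC[C@@H]2C=C[C@H](n3cc(C)c(=O)[nH]c3=O)O2)cc1` differs from compound 2 by octyl in place of hydrogen on a saturated chain carbon, nine bonds along the chain from a carbonyl carbon. No step between two measured compounds covers this change, so the direction and size of its effect are not shown by the data. The expectation is that the step from compound 2 to compound 4, a number no higher from compound 2 to compound 4 (the limit leaves the size open), stays within the scatter, and that compound 4 is likely again reported only at the limit of this assay. Compound 4 is estimated at 30 h, with a range from 15 h to 60 h.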

Compound 4, half-life: > 30 h
Compound 4: a limit, no number; the forecaster's own chance of this, stated with the estimate: 70%; the middle value sits exactly at the limit.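

Compound 2 and compound 4 are both reported only as limits, so no step can be read between them: the limit of > 30 h in this assay, at which 2 of the 4 values shown sit.

The compounds shown leave open whether octyl in place of hydrogen on this chain changes the half-life in this assay at all.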